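The source may hold more compounds than are shown below. What is called first, only, known or untested is meant among the compounds shown, and "the series" means these compounds.

Two compounds have been measured so far in an ADME assay on the whole organism (plasma) for pharmacokinetics, with Rattus norvegicus as the target, with a stated time of 6 h, at a dose of 10 mg/kg by the oral route (on this read-out higher numbers stand for higher exposure at the dose given and lower numbers for lower exposure), for now:

Compound 1 `C=CCNC(=O)C(=O)C(CCC)NC(=O)[C@@H]1[C@@H]2[C@H](CN1C(=O)[C@@H](NC(=O)N[C@H](COC(=O)NCC)C(C)(C)C)C1Cc3ccccc3C1)C2(C)C` gives 496 ng.h/mL
Compound 2 `C=CCNC(=O)C(=O)C(CCC)NC(=O)[C@@H]1[C@@H]2[C@H](CN1C(=O)[C@@H](NC(=O)N[C@H](COC(=O)NC(C)C)C(C)(C)C)C1(C)CCCCC1)C2(C)C` gives 4640 ng.h/mL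

Compound 2 stands highest of the two, and its gap to compound 1 lies beyond the usual scatter. These two differ in more than one place, so the gap cannot be tied to any single change. Compound 3 `C#CCCC(NC(=O)[C@@H]1[C@@H]2[C@H](CN1C(=O)[C@@H](NC(=O)N[C@H](COC(=O)NC(C)C)C(C)(C)C)C1(C)CCCCC1)C2(C)C)C(=O)C(=O)NCC=C` differs from compound 2 by one change (ethynyl in place of methyl on a saturated chain carbon, three bonds along the chain from an amide-type nitrogen and a carbonyl carbon): ethynyl in place of methyl on a saturated chain carbon, three bonds along the chain from an amide-type nitrogen and a carbonyl carbon. Within the data shown here, no measured pair shows this change, so no step beyond the scatter is expected in this assay here. The estimated step is a 1.5-fold lower number from compound 2 to compound 3 (0.19 log units; within the scatter) and would stay within that scatter. For compound 3 the estimated value is 3000 ng.h/mL with an expected range from 900 ng.h/mL to 9000 ng.h/mL on this read-out.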

Compound 3, area under the concentration-time curve: 5630 ng.h/mL
Estimate against measurement, compound 3: 1.9-fold (0.27 log units) below; low and high end bracket the measured number.
By their numbers in this assay, from the lowest: compound 1; then compounds 2 and 3 (each within the scatter of the next).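

Replacing the propyl chain of compound 2 with but-3-yn-1-yl gives, in this assay, a 1.2-fold higher number from compound 2 to compound 3 (0.08 log units; within the scatter), so at this place on the chain, ethynyl in place of methyl leaves exposure in the rat indistinguishable from that of compound 2. Among these compounds, this single pair is the first direct reading of any one-place change, and no supporting measurement here accounts for the result. Still open, on these data alone, is whether a hydroxyl, an amine or a phenyl ring at this place would also keep exposure, and whether ethynyl would do the same on compound 1.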